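A Larger Group on the Aromatic Carbon

The compounds below may be only part of what the source reports. "The series", "measured", "known", "first", "only" and "open" are said of these compounds alone.

Measured in a physicochemical assay for solubility, at pH 7.4; a lower number here means a less soluble compound, a higher number a more soluble compound:
- Compound 1 `CNC1(C)CN(c2c(F)cc3c(=O)c(C(=O)O)cn(C4CC4)c3c2F)C1`: 0.5 ug/mL
- Compound 2 `C[C@H]1[C@@H](N)CN1c1c(F)cc2c(=O)c(C(=O)O)cn(C3CC3)c2c1F`: 23.6 ug/mL

Of these two compounds, compound 2 stands higher, at 23.6 ug/mL, while compound 1 gives 0.5 ug/mL. The next compound to be tested in this assay is compound 3 `CN(C)C1CN(c2c(F)cc3c(=O)c(C(=O)O)cn(C4CC4)c3c2F)C1`. It differs from compound 2 by a group of 7 heavy atoms (5 carbon, 2 nitrogen; one four-membered non-aromatic ring with 1 hetero atom) in place of a group of 6 heavy atoms (4 carbon, 2 nitrogen; one four-membered non-aromatic ring with 1 hetero atom), on an aromatic carbon: a 3-(dimethylamino)azetidin-1-yl group now sits on the aromatic carbon, ortho to two fluoro groups.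

Among the measured compounds shown here, only one measured step bears on this change. It is a 47-fold higher number from compound 1 to compound 2 (1.67 log units; beyond the scatter), a large step beyond the scatter, and it also exchanges one group for another on an aromatic carbon. There, the group of 6 heavy atoms replaced a group of 7 heavy atoms and the number rose. The change to compound 3 runs the other way in size, so a fall is expected, though a single step is thin evidence and the fall may be smaller. The expected step is a 7.9-fold lower number from compound 2 to compound 3 (0.90 log units; beyond the scatter). For compound 3 the estimate is 3 ug/mL, with an expected range from 0.6 ug/mL to 15 ug/mL.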

Compound 3, solubility: 58 ug/mL
For compound 3 the middle estimate is 19-fold (1.29 log units) below the measured one, outside the stated range (above it).
By their numbers in this assay, from the lowest: compound 1; then compound 2; then compound 3.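

In this assay, the step of a 2.5-fold higher number from compound 2 to compound 3 (0.39 log units; beyond the scatter) shows that a group of 7 heavy atoms on this aromatic carbon, ortho to two fluoro groups, need not give a lower number than a group of 6 heavy atoms, so the size of the group alone does not order these compounds. The step of a 120-fold higher number from compound 1 to compound 3 (2.06 log units; beyond the scatter) sharpens this, since 3-(dimethylamino)azetidin-1-yl and 3-methyl-3-(methylamino)azetidin-1-yl have the same count of heavy atoms and the same four-membered non-aromatic ring, and the number still moves a long way at this one position. Nothing available explains either step.

The compounds shown leave open where a piperazin-1-yl or a 3-hydroxyazetidin-1-yl group on the same aromatic carbon would stand among these three. Going by these compounds, it also remains open how much of the difference between compound 2 and compound 3 goes with the 2 defined stereocentres of the group that leaves, and how much with its 1 hydrogen-bond donor, since the two features change together in this step.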